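From chloro to bromo at a reporting limit

This account rests on a few compounds, and the source may have more. Where it says the series, first, only, none or still open, it means among the compounds named here.

In an ADME assay on HEK293 cells (Homo sapiens) for cytotoxicity, read by luminescence, with a stated time of 72 h (on this read-out higher numbers stand for an effect only at larger amounts of compound and lower numbers for an effect already at smaller amounts), compound 3 `CCOC(=O)c1c(-c2cccc(Cl)c2)[nH]c2cc(OC)c(F)cc2c1=O` gives > 22000 nM, which is a limit and not a number. Compound 1 `CCOC(=O)c1c(-c2cccc(Br)c2)[nH]c2cc(OC)c(Cl)cc2c1=O` gives > 22000 nM, also a limit. Compound 2 `CCOC(=O)c1c(-c2cccc(-c3ccccc3)c2)[nH]c2cc(OC)c(F)cc2c1=O` gives > 22000 nM, again a limit. Compound 3 therefore has no exact place among its neighbours, and the whole picture so far is the limit of > 22000 nM in this assay, at which 3 of the 3 values shown sit.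

Compound 4 `CCOC(=O)c1c(-c2cccc(Br)c2)[nH]c2cc(OC)c(F)cc2c1=O` differs from compound 3 by a single swap, bromo in place of chloro on an aromatic carbon.

Among the measured compounds shown here, only one measured change bears on this swap, a step that the two limits leave unreadable from compound 2 to compound 3, with chloro in place of phenyl on an aromatic carbon. Both ends of that step sit at the limit, so it offers no size to carry over. With nothing measured to suggest otherwise, no step beyond the usual scatter is expected in this assay, and the expected change is a step that the limit leaves unreadable from compound 3 to compound 4. Compound 4 is estimated at 25000 nM, within a range of 12000 nM to 50000 nM, and will most likely be reported only as a limit again.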

Compound 4, half-maximal effective concentration: > 22000 nM
Compound 4 was reported as a limit (the forecaster's own chance of this, stated with the estimate: 85%); the middle value lies beyond the limit too.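

Compound 4, like compound 1, compound 2 and compound 3, gives only a limit and not a number, so no step between them can be read: the limit of > 22000 nM in this assay, at which 4 of the 4 values shown sit.

Whether bromo in place of chloro changes anything in this assay stays open, as does the concentration at which any of these compounds would show an effect.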